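The compounds below may be only part of what the source reports. "The series", "measured", "known", "first", "only" and "open" are said of these compounds alone.

Compound 1 `COc1cc(OC)n2cc(-c3ccc([N+](=O)[O-])cc3)nc2n1` and compound 2 `COc1cc(OC)n2cc(-c3ccc(N)cc3)nc2n1` share one core and differ by amino in place of nitro on an aromatic carbon. In a functional assay on HepG2 cells (Homo sapiens) for antiproliferative activity, read by MTT assay, with a stated time of 72 h (on this read-out higher numbers stand for weaker inhibition of growth and lower numbers for stronger inhibition of growth), compound 1 gives 35900 nM. Compound 2 reaches only a limit of this assay, > 100000 nM. The step of an at least 2.7-fold higher number from compound 1 to compound 2 (0.44 log units; beyond the scatter) therefore points toward weaker inhibition of growth, with compound 2 resting at the limit of > 100000 nM in this assay, at which 2 of the 3 values shown sit. Compound 3 `Cc1ccc2nc(-c3ccc([N+](=O)[O-])cc3)cn2c1` is built on another core; the difference between the two cores is not broken down here. In this assay compound 3 gives only a limit, > 100000 nM. Compound 4 `Cc1ccc2nc(-c3ccc(N)cc3)cn2c1` differs from compound 3 by amino in place of nitro on an aromatic carbon, the same kind of change as between compound 1 and compound 2. Because that change produced an at least 2.7-fold higher number from compound 1 to compound 2 (0.44 log units; beyond the scatter), compound 4 is expected to remain beyond the limit, estimated at 250000 nM with a range from 100000 nM to 1000000 nM. That estimate corresponds to an expected step that the limit leaves unreadable from compound 3 to compound 4.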

Compound 4, concentration for 50% growth inhibition: > 100000 nM
Compound 4 gave a limit, no number; the forecaster's own chance of this, stated with the estimate: 90%; the middle value is on the limit's open side.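

Going by these compounds alone, compound 3 and compound 4 both give only a limit in this assay, and no step between them can be read. The compounds shown leave open whether amino in place of nitro changes inhibition of growth at all on the core of compound 3.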